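The compounds below may be only part of what the source reports. "The series", "measured", "known", "first", "only" and "open" are said of these compounds alone.

For the measured compounds named here, compound 3 `CCCCCCc1cn([C@H]2C[C@H](O)[C@@H](CO)O2)c(=O)[nH]c1=O` is the one member of this small set for which a functional assay on L1210 cells (Mus musculus) (a higher number here means a weaker inhibitor, a lower number a stronger inhibitor), yields a number: in this assay compound 3 gives 301 ug/mL. Compound 1 `O=c1[nH]c(=O)n([C@H]2C[C@H](O)[C@@H](CO)O2)cc1C#CCCO` gives only a limit, > 1000 ug/mL in this assay. Compound 2 `CCC#Cc1cn([C@H]2C[C@H](O)[C@@H](CO)O2)c(=O)[nH]c1=O` likewise gives only a limit, > 1000 ug/mL in this assay. Because of the limit of > 1000 ug/mL in this assay, at which 2 of the 3 values shown sit, the change from compound 1 to compound 2 is a step that the two limits leave unreadable from compound 1 to compound 2. Against that limit the hexyl compound stands apart: an at least 3.3-fold lower number from compound 1 to compound 3 (0.52 log units; beyond the scatter) and an at least 3.3-fold lower number from compound 2 to compound 3 (0.52 log units; beyond the scatter).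

Compound 4 `CCCC#Cc1cn([C@H]2C[C@H](O)[C@@H](CO)O2)c(=O)[nH]c1=O` carries pent-1-yn-1-yl in place of hexyl on an aromatic carbon. The step that bears most on it is the one measured in the opposite direction, an at least 3.3-fold lower number from compound 2 to compound 3 (0.52 log units; beyond the scatter), where compound 2 with its but-1-yn-1-yl gave only a limit and compound 3 with hexyl gave a number; compound 4 returns to a chain with a triple bond outside aromatic rings, as in compound 2. The chemist therefore expects compound 4 to move back toward the limit, an estimated 3.3-fold higher number from compound 3 to compound 4 (0.52 log units; beyond the scatter) in this assay. Her estimate for compound 4 in this assay is 1000 ug/mL, ranging from 350 ug/mL to 3000 ug/mL, with a fair chance that only a limit is reported.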

Compound 4, concentration for 50% inhibition: > 1000 ug/mL
Compound 4 gave a limit, no number (the forecaster's own chance of this, stated with the estimate: 55%); the middle value lies on the limit itself.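

At the aromatic carbon two atoms from the ring nitrogen, pent-1-yn-1-yl in place of hexyl gives an at least 3.3-fold higher number from compound 3 to compound 4 (0.52 log units; beyond the scatter) in this assay. The pent-1-yn-1-yl chain of compound 4 ends in a limit, as does the but-1-yn-1-yl chain of compound 2, so this longer chain with a triple bond brings no readable number. Among the four compounds, all three with a triple bond stay at a limit and only compound 3 gives a number, with none going against this, while the steps from compound 1 and from compound 2 to compound 4 cannot be read because of this: the limit of > 1000 ug/mL in this assay, at which 3 of the 4 values shown sit.

The step from compound 3 to compound 4 changes chain length and triple bond together, and the compounds shown do not separate the two. From the compounds shown here alone, whether a pentyl chain, a chain longer than hexyl, or an amine at the chain end would give a number stays open.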